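From propyl to isopropyl on an aromatic nitrogen

The source may hold more compounds than are shown below. What is called first, only, known or untested is meant among the compounds shown, and "the series" means these compounds.

In a functional assay on cells (Platelet, Homo sapiens) for inhibition (a higher number here means a weaker inhibitor, a lower number a stronger inhibitor), three compounds sharing one core have been measured: compound 1 (`CCOC(=O)c1ccc(-c2nn(Cc3ccc(OC)cc3)c3ccccc23)cc1`), compound 2 (`CCOC(=O)c1ccc(-c2nn(Cc3ccncc3)c3ccccc23)cc1`) and compound 3 (`CCCn1nc(-c2ccc(C(=O)OCC)cc2)c2ccccc21`). Compound 1 reads > 10000 nM as a limit of the assay and not a number. Compound 2 reads > 10000 nM as a limit as well. Compound 3 reads > 10000 nM as a limit too, so it offers no number to start from (the limit of > 10000 nM in this assay, at which 3 of the 3 values shown sit).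

Compound 4 (`CCOC(=O)c1ccc(-c2nn(C(C)C)c3ccccc23)cc1`) differs from compound 3 by a single change (isopropyl in place of propyl on an aromatic nitrogen) with isopropyl in place of propyl on an aromatic nitrogen. Two measured steps alter the group on that nitrogen (a step that the two limits leave unreadable from compound 1 to compound 3; a step that the two limits leave unreadable from compound 2 to compound 3) and neither has a readable size. With no size to carry over, no step beyond the scatter is expected in this assay and no direction can be given. The expected change is small (a step that the limit leaves unreadable from compound 3 to compound 4). Compound 4 is estimated at 15000 nM with an expected range from 5000 nM to 40000 nM, and the expected outcome may again be only a limit.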

Compound 4, half-maximal inhibitory concentration: > 10000 nM
Compound 4: only a limit was reported; the forecaster's own chance of this, stated with the estimate: 85%; the middle value lies beyond the limit too.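

In this assay compound 4 gives > 10000 nM, a limit and not a number. Among the compounds shown here, no step from compound 1, compound 2 or compound 3 to compound 4 can be read. The compounds shown leave open whether the group on the aromatic nitrogen changes inhibition at all: the limit of > 10000 nM in this assay, at which 4 of the 4 values shown sit.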